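Side-chain swap from compound 3 toward unmeasured compound 4

A few compounds are considered here, and "the series" means these few. Any claim that something is new, unique, unknown or untested is made for them only; others in the source may bear on it.

Measured so far, in a functional assay on MCF7 cells (Homo sapiens) for antiproliferative activity, read by MTT assay, with a stated time of 72 h; on this read-out higher numbers stand for weaker inhibition and lower numbers for stronger inhibition:
compound 1 `CCN1CCN(c2cc(C)c3cc(NC(=O)c4cccnc4)ccc3n2)CC1` gives 26600 nM
compound 2 `CCN1CCN(c2cc(C)c3cc(NC(=O)c4cccc(C)c4)ccc3n2)CC1` gives 7800 nM
compound 3 `Cc1cc(NCCN2CCCC2)nc2ccc(NC(=O)c3ccc(Cl)c(Cl)c3)cc12` gives 1280 nM

Compound 3 stands lowest of the three numbers; compound 2 is nearest, compound 1 furthest, both gaps beyond the scatter. For the measured compounds named here, the only one-place step among the measured compounds is a 3.4-fold lower number from compound 1 to compound 2 (0.53 log units; beyond the scatter), which concerns the amide portion and leaves the side chain on the shared core untouched.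

Compound 4 `CCN1CCN(c2cc(C)c3cc(NC(=O)c4ccc(Cl)c(Cl)c4)ccc3n2)CC1` keeps the amide of compound 3 and the core of compound 1 and compound 2, but differs from compound 3 as follows: 4-ethylpiperazin-1-yl in place of (2-(pyrrolidin-1-yl)ethyl)amino on an aromatic carbon. Going by the values given here, no measured pair shows this change on its own, so the step from compound 1 to compound 2 does not bear on it directly; it only shows that amide changes on the ethylpiperazinyl-bearing core shift the numbers modestly. Given that the two side chains match in heavy-atom count and acceptor count and differ mainly in the donor and the ring, a step of moderate size in either direction in this assay is considered possible, with a weakening expected as the more likely outcome since compound 3 holds the lowest number seen.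

Compound 4 is estimated at 3000 nM, within 700 nM to 13000 nM, corresponding to an expected step of a 2.3-fold higher number from compound 3 to compound 4 (0.37 log units; beyond the scatter).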

Compound 4, half-maximal inhibitory concentration in the MCF7 assay: 1380 nM
Beside the measured number, compound 4's estimate is 2.2-fold (0.34 log units) above it, and the stated range covers the measured number.
By their numbers in the MCF7 assay, from the lowest: compounds 3 and 4 (each within the scatter of the next); then compound 2; then compound 1.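

In the MCF7 assay, the swap on the aromatic carbon next to the ring nitrogen gives a step within the scatter (a 1.1-fold higher number from compound 3 to compound 4 (0.03 log units; within the scatter)), so 4-ethylpiperazin-1-yl and (2-(pyrrolidin-1-yl)ethyl)amino are not told apart on this read-out, although the entering group has no hydrogen-bond donor and a six-membered ring with 2 hetero atoms. With 4-ethylpiperazin-1-yl held fixed, the amide portion carries the larger steps, both for 3,4-dichlorophenyl in place of 3-methylphenyl (a 5.7-fold lower number from compound 2 to compound 4 (0.75 log units; beyond the scatter)) and for 3,4-dichlorophenyl in place of pyridin-3-yl (a 19-fold lower number from compound 1 to compound 4 (1.29 log units; beyond the scatter)). The side-chain swap that leaves the number in the MCF7 assay level does separate the pair in a physicochemical assay for solubility; on this read-out higher numbers stand for higher solubility and lower numbers for lower solubility: the measured solubility of compound 3, 84.5 ug/mL, and of compound 4, 11.3 ug/mL, a 7.5-fold lower number (0.87 log units; beyond the scatter). In the physicochemical assay compound 3 gives 84.5 ug/mL and compound 4 gives 11.3 ug/mL.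

From the compounds shown here alone, the side-chain comparison rests on one pair carrying the 3,4-dichlorophenyl amide, so whether it holds with the 3-methylphenyl or pyridin-3-yl amides stays open. Also open, going by these compounds, is where a morpholine ring or the longer chain (3-(pyrrolidin-1-yl)propyl)amino at this position would fall in the MCF7 assay and in the physicochemical assay.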